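Alkyl-to-cyclohexylmethyl change at the aromatic carbon: compound 4

The source may hold more compounds than are shown below. What is called first, only, known or untested is meant among the compounds shown, and "the series" means these compounds.

Compound 1 `CNc1nc(-n2cc(-c3ccccn3)nn2)nc2c1ncn2[C@@H]1O[C@H](CO)[C@@H](O)[C@H]1O`, compound 2 `CCc1cn(-c2nc(NC)c3ncn([C@@H]4O[C@H](CO)[C@@H](O)[C@H]4O)c3n2)nn1` and compound 3 `CCCCc1cn(-c2nc(NC)c3ncn([C@@H]4O[C@H](CO)[C@@H](O)[C@H]4O)c3n2)nn1` share one core and differ only in the group on an aromatic carbon. In an assay on CHO cells for displacement of a labelled ligand from adenosine receptor A1 (Homo sapiens) (a higher number here means a weaker inhibitor, a lower number a stronger inhibitor), compound 1 gives 1970 nM, compound 2 gives 2920 nM and compound 3 gives 848 nM, the lowest of the three numbers. The steps of a 2.3-fold lower number from compound 1 to compound 3 (0.37 log units; beyond the scatter) and a 3.4-fold lower number from compound 2 to compound 3 (0.54 log units; beyond the scatter) both lie beyond the scatter, whereas a 1.5-fold higher number from compound 1 to compound 2 (0.17 log units; within the scatter) does not. Compound 4 `CNc1nc(-n2cc(CC3CCCCC3)nn2)nc2c1ncn2[C@@H]1O[C@H](CO)[C@@H](O)[C@H]1O` carries cyclohexyl in place of propyl on a saturated chain carbon bound to an aromatic carbon. Among the measured compounds shown here, both measured steps ending at compound 3 lowered the number, and the change to compound 4 is treated as a continuation of that direction; the expected step is a 1.7-fold lower number from compound 3 to compound 4 (0.23 log units; within the scatter), a modest lowering, though no measured step contains a ring at this place. For compound 4 the estimate is 500 nM, within 150 nM to 1700 nM.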

Compound 4, inhibition constant: 1430 nM
Estimate against measurement, compound 4: 2.9-fold (0.46 log units) below, within the range that was stated.
By their numbers in this assay, from the lowest: compounds 3, 4, 1 and 2 (each within the scatter of the next, the first and the last beyond it).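

In this assay a saturated ring first appears at this aromatic carbon, and a 1.7-fold higher number from compound 3 to compound 4 (0.23 log units; within the scatter) stays within the scatter, as does a 1.4-fold lower number from compound 1 to compound 4 (0.14 log units; within the scatter) against the pyridin-2-yl group. Only a 2.0-fold lower number from compound 2 to compound 4 (0.31 log units; beyond the scatter) lies beyond it, so cyclohexylmethyl here reads level with butyl and pyridin-2-yl, and modestly apart from ethyl. Nothing available bears on the reason for this result. Open, on these data alone, is whether a hexyl chain or a cyclohexyl ring held directly on the aromatic carbon would read the same. As far as these compounds go, an amine or a carboxylic acid at the end of the chain also remains open.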